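The source may report more compounds than this note shows. Statements on the series, on what has been measured and on what is new or still open speak of the compounds shown alone.

Compound 1 `CCCCC(N)c1cc(C(F)(F)F)ccc1N1CCN(C(=O)CCc2ccc(Cl)cc2Cl)CC1`: 190 nM in an assay on HEK293 cells for displacement of a labelled ligand from Melanocortin receptor 4 (Homo sapiens); a lower number here means a stronger inhibitor, a higher number a weaker inhibitor.
Compound 2 `CC[C@H](C)C(N)c1cc(C(F)(F)F)ccc1N1CCN(C(=O)CCc2ccc(Cl)cc2Cl)CC1`: 75 nM in this assay.

Compound 2 stands lowest of the two numbers, with compound 1 as its nearest neighbour a 2.5-fold lower number from compound 1 to compound 2 (0.40 log units; beyond the scatter). Within the data shown here, that step swaps the butyl for a sec-butyl on the carbon that carries the amine and the aromatic ring, and it is the only measured step available.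

Compound 3 `CCC(C)C(N)c1cc(C(F)(F)F)ccc1N1CCN(C(=O)CCc2ccc(Cl)cc2Cl)CC1` differs from compound 2 only in how that carbon is drawn: the two compounds have the same atoms and bonds; at least one stereo element is drawn with a configuration in one of them and without one in the other: 1 of 2 stereo elements differ; a stereocentre at a saturated chain carbon is drawn S in compound 2 and without a configuration in compound 3. No atoms leave or enter. Among the measured compounds shown here, the step from compound 1 to compound 2 changed the chain itself and does not speak to the drawn configuration, so no measured step bears directly on this change. The expectation is a number near that of compound 2, or somewhat higher, within what a single undrawn centre usually brings a 1.5-fold higher number from compound 2 to compound 3 (0.17 log units; within the scatter).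

The estimate for compound 3 in this assay is 110 nM, expected to fall between 50 nM and 300 nM.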

Compound 3, inhibition constant: 160 nM
For compound 3 the middle estimate is 1.5-fold (0.16 log units) below the measured one; the range from low to high includes it.
By their numbers in this assay, from the lowest: compound 2; then compounds 3 and 1 (each within the scatter of the next).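

The same atoms and bonds do not give one fixed number in this assay: a 2.1-fold higher number from compound 2 to compound 3 (0.33 log units; beyond the scatter). The only difference between these two compounds is this: the fact that one of compounds 2 and 3 is drawn with a defined configuration and the other without, at the place where they differ. With no configuration drawn at that centre, sec-butyl is not separated from butyl, a 1.2-fold lower number from compound 1 to compound 3 (0.07 log units; within the scatter), whereas the form drawn S is, a 2.5-fold lower number from compound 1 to compound 2 (0.40 log units; beyond the scatter), so the earlier step cannot be credited to the branched chain alone.

The compounds shown leave open what the form drawn R at that centre would give, and what a defined configuration would give at the second stereo element, which is the same in compound 2 and compound 3. They also leave open how an isopropyl, tert-butyl or cyclohexyl group would compare on the carbon that carries the amine and the aromatic ring.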